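This account rests on a few compounds, and the source may have more. Where it says the series, first, only, none or still open, it means among the compounds named here.

Two compounds of this series have been measured in an assay on CHO cells for displacement of a labelled ligand from adenosine receptor A2b (Homo sapiens), read by radioligand binding; on this read-out higher numbers stand for weaker inhibition and lower numbers for stronger inhibition:

compound 1, `CCOc1cccc2cc(-c3ccccc3)c(=O)oc12`: > 30000 nM
compound 2, `CCOc1cccc2cc(-c3ccc(OC)cc3)c(=O)oc12`: > 30000 nM

In this assay compound 1 gives > 30000 nM, which is a limit of the assay and not a number. In this assay compound 2 gives > 30000 nM, again a limit of the assay rather than a number. Compound 2 therefore stands at the limit, with no number to place it more closely. Among the compounds with values here, the only step between measured compounds, a step that the two limits leave unreadable from compound 1 to compound 2, cannot be read as a size because of the limit of > 30000 nM in this assay, at which 2 of the 2 values shown sit.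

Compound 3, `CCOc1cccc2cc(-c3ccc([N+](=O)[O-])cc3)c(=O)oc12`, differs from compound 2 by nitro in place of methoxy on an aromatic carbon. Within the data shown here, no measured step bears on this change, so no direction or size can be drawn from the data. Both measured compounds sit at the limit, and the expectation for compound 3 rests only on that. The estimate for compound 3 in this assay is 40000 nM, with a range from 10000 nM to 150000 nM, most likely reported again as a limit. The expected step that the limit leaves unreadable from compound 2 to compound 3 is thus none beyond the scatter.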

Compound 3, inhibition constant: > 30000 nM
Compound 3 was reported as a limit; the forecaster's own chance of this, stated with the estimate: 85%; the middle value lies beyond the limit too.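

In this assay compound 3 gives > 30000 nM, again a limit of the assay and not a number. Within the data shown here, no step among compound 1, compound 2 and compound 3 can be read, because all three stand at one limit: the limit of > 30000 nM in this assay, at which 3 of the 3 values shown sit. The compounds shown leave open whether methoxy or nitro in place of hydrogen changes inhibition at all.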